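Thiosemicarbazone in place of formyl and red-cell hemolysis

This account rests on a few compounds, and the source may have more. Where it says the series, first, only, none or still open, it means among the compounds named here.

Compound 1 `NC(=S)N/N=C/c1ccc(OCc2ccc3no[n+]([O-])c3c2)cc1`: > 200 uM, a limit of the assay.
Compound 2 `O=Cc1ccc(OCc2ccc3no[n+]([O-])c3c2)cc1`: < 50 uM, a limit of the assay.
Compound 3 `CC1(C)[N+]([O-])=c2ccc(COc3cccc(C=O)c3)cc2=[N+]1[O-]`: < 50 uM, a limit of the assay.

In an ADME assay on cells (Erythrocyte, Homo sapiens), read by spectrophotometry and hemolysis, with a stated time of 24 h (a higher number here means a weaker inhibitor, a lower number a stronger inhibitor), compound 2 reaches only a limit, < 50 uM, not a number. Compound 1 likewise reaches only a limit, > 200 uM. The change between them is a group of 6 heavy atoms (2 carbon, 3 nitrogen, 1 sulfur; no ring) in place of a group of 2 heavy atoms (1 carbon, 1 oxygen; no ring), on an aromatic carbon, and it gave an at least 4.0-fold higher number from compound 2 to compound 1 (0.60 log units; beyond the scatter). That step is known only as a lower bound because the limit of < 50 uM in this assay, at which 2 of the 3 values shown sit, and the limit of > 200 uM in this assay, at which 1 of the 3 values shown sits, cap both values.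

Compound 3 also sits at a limit in this assay, < 50 uM. The difference between the core of compound 2 and the core of compound 3 is not broken down here.

Compound 4 `CC1(C)[N+]([O-])=c2ccc(COc3cccc(/C=N/NC(N)=S)c3)cc2=[N+]1[O-]` has not been measured. It differs from compound 3 by a group of 6 heavy atoms (2 carbon, 3 nitrogen, 1 sulfur; no ring) in place of a group of 2 heavy atoms (1 carbon, 1 oxygen; no ring), on an aromatic carbon. The place lines differ: in compound 1 the new group stands para to a large group, in compound 4 meta to a large group, so this is the same kind of change, not the same change. The step is expected to be an at least 5.0-fold higher number from compound 3 to compound 4 (0.69 log units; beyond the scatter), resting on an at least 4.0-fold higher number from compound 2 to compound 1 (0.60 log units; beyond the scatter). Compound 4 is therefore estimated at 250 uM, most likely reported only as a limit.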

Compound 4, concentration for 50% inhibition: 141 uM
Compound 4: the middle estimate sits 1.8-fold (0.25 log units) above what was measured; low and high end bracket the measured number.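

In this assay, putting the thiosemicarbazone in place of formyl on the core of compound 3, where it stands meta to a large group, gives an at least 2.8-fold higher number from compound 3 to compound 4 (0.45 log units; beyond the scatter). The change therefore raises the number on both cores shown, and the direction carries from one core to the other: the same change on two cores in this assay, an at least 4.0-fold higher number (0.60 log units; beyond the scatter) from compound 2 to compound 1 and an at least 2.8-fold higher number (0.45 log units; beyond the scatter) from compound 3 to compound 4; the limit leaves it open whether they differ Both steps start from a value that is a limit of the assay, so each gives only a floor for the real step, and two cores show that the direction held twice, not that it holds across the series or that its size stays the same.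

The compounds shown leave open which part of the entering group goes with the higher number, for instance whether a semicarbazone, with oxygen in place of the sulfur, or a plain hydrazone would give the same step. Also open, as far as these compounds go, is how far the formyl compounds themselves lie under their limits, and with that the true size of both steps.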